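Benzylic position of the aryl sulfone: hydroxyl removal

The source may hold more compounds than are shown below. What is called first, only, known or untested is meant among the compounds shown, and "the series" means these compounds.

For the measured compounds named here, compound 2 `O=C(NO)C(CCCc1ccccc1)CS(=O)(=O)c1ccc(C(O)c2ccccc2)cc1` gives 2500 nM in an assay on isolated protein for inhibition of matrix metalloproteinase-9 (Homo sapiens) (on this read-out lower numbers stand for stronger inhibition and higher numbers for weaker inhibition), the highest of the two numbers so far. Going by the values given here, its nearest neighbour is compound 1 `O=C(c1ccccc1)c1ccc(S(=O)(=O)CC(CCCc2ccccc2)C(=O)NO)cc1`, which gives 5 nM in this assay; the only measured step, a 500-fold higher number from compound 1 to compound 2 (2.70 log units; beyond the scatter), corresponds to hydroxy(phenyl)methyl in place of benzoyl on an aromatic carbon.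

Compound 3 `O=C(NO)C(CCCc1ccccc1)CS(=O)(=O)c1ccc(Cc2ccccc2)cc1` has not been measured. Its change from compound 2 is hydrogen in place of hydroxy on a saturated chain carbon bound to two aromatic carbons, which cut one bond further out reads hydroxy(phenyl)methyl to benzyl. Among the compounds with values here, no measured step repeats this change. The step from compound 1 to compound 2 bears on it only indirectly: that step removed the carbonyl and introduced the hydroxy together, and compound 3 now loses the hydroxy without regaining the carbonyl. The direction of the large step from compound 1 to compound 2 suggests that the hydroxy(phenyl)methyl form is the weakest arrangement seen, so a move away from it is expected to lower the number, but by a smaller margin than a 500-fold higher number from compound 1 to compound 2 (2.70 log units; beyond the scatter).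

For compound 3 the expected step is a 5.0-fold lower number from compound 2 to compound 3 (0.70 log units; beyond the scatter), giving an estimated 500 nM in this assay, with a range from 50 nM to 5000 nM.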

Compound 3, half-maximal inhibitory concentration: 150 nM
For compound 3 the middle estimate is 3.3-fold (0.52 log units) above the measured one; the range from low to high includes it.
By their numbers in this assay, from the lowest: compound 1; then compound 3; then compound 2.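

In this assay the hydroxy on the saturated chain carbon bound to two aromatic carbons turns out to matter in its own right: a 17-fold lower number from compound 2 to compound 3 (1.22 log units; beyond the scatter) is a large step with only that one atom exchanged for hydrogen, so part of the rise in a 500-fold higher number from compound 1 to compound 2 (2.70 log units; beyond the scatter) goes with the hydroxy and not only with the lost carbonyl. Even so, removing the hydroxy does not restore the benzoyl level: a 30-fold higher number from compound 1 to compound 3 (1.48 log units; beyond the scatter) is also a large step, which shows that the change from benzoyl to benzyl alone, with no hydroxy involved, still costs much of the original number, and that compound 1 remains the lowest of the three. Nothing available here accounts for either step.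

Still open, on these data alone, is whether other linking groups in this place, such as an ether oxygen, a sulfonyl or an oxime, would come close to the benzoyl number or stay nearer the benzyl one. Equally open, as far as these compounds go, is how an amine or a methoxy on the same carbon would compare with the hydroxy, and whether the two mirror-image forms of compound 2 read alike.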